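Swapping pyridin-4-yl for phenethyl on a beta-lactam acid

The compounds below may be only part of what the source reports. "The series", "measured", "known", "first", "only" and "open" are said of these compounds alone.

Measured so far:
- Compound 1, `CC(C)(C)C1=C(C(=O)O)N2C(=O)[C@H]([C@H](O)CCc3ccccc3)[C@H]2O1`: 21 h
- Compound 2, `C[C@H](O)[C@H]1C(=O)N2C(C(=O)O)=C(C(C)(C)C)O[C@H]12`: 7.1 h
- Compound 3, `CC(C)(C)C1=C(C(=O)O)N2C(=O)[C@H]([C@@H](O)c3ccncc3)[C@H]2O1`: 6 h

All three share one core and differ only in the group carried on a saturated chain carbon that bears a hydroxyl. In an ADME assay, in phosphate buffer, at 28 degrees C, at pH 7.0 (on this read-out lower numbers stand for a shorter-lived compound and higher numbers for a longer-lived compound), compound 3 gives 6 h, the lowest of the three numbers; compound 2 sits close, and compound 1 is clearly further away, giving 21 h in this assay.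

Compound 4, `CC(C)(C)C1=C(C(=O)O)N2C(=O)[C@H]([C@@H](O)CCc3ccccc3)[C@H]2O1`, is not yet measured. It differs from compound 3 in one place: phenethyl in place of pyridin-4-yl on a saturated chain carbon bound to an oxygen on a saturated carbon and a saturated ring carbon.

Within the data shown here, only one measured step is available, and it does not match this change: a 1.2-fold lower number from compound 2 to compound 3 (0.07 log units; within the scatter). That step exchanged methyl for pyridin-4-yl and moved the number hardly at all. Among the measured compounds shown here, no measured step exchanges pyridin-4-yl for phenethyl. Compound 1 also carries phenethyl at this place and shows a higher number than compound 3, which suggests the change toward compound 4 may lengthen the half-life somewhat, though compound 1 and compound 4 are not otherwise identical, so this is a loose guide.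

Compound 4 is therefore expected to show a 2.2-fold higher number from compound 3 to compound 4 (0.34 log units; beyond the scatter), a modest rise that may or may not clear the scatter. The estimate for compound 4 in this assay is 13 h, with a likely range from 6.5 h to 26 h.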

Compound 4, half-life: 39 h
Beside the measured number, compound 4's estimate is 3.0-fold (0.48 log units) below it; measured number above the stated range.
By their numbers in this assay, from the lowest: compounds 3 and 2 (each within the scatter of the next); then compounds 1 and 4 (each within the scatter of the next).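

In this assay, the move to phenethyl gives a 6.5-fold higher number from compound 3 to compound 4 (0.81 log units; beyond the scatter), whereas the earlier exchange of methyl for pyridin-4-yl gave only a 1.2-fold lower number from compound 2 to compound 3 (0.07 log units; within the scatter), so this position can clearly shift the half-life, depending on the group it carries. The second route to compound 4, with benzyl in place of hydrogen on the chain, points the same way and gives a 5.5-fold higher number from compound 2 to compound 4 (0.74 log units; beyond the scatter), placing both phenethyl compounds at the upper end of the series and the methyl and pyridin-4-yl compounds at the lower end. The drawn configuration at this saturated chain carbon shows no effect beyond the scatter, with a 1.9-fold higher number from compound 1 to compound 4 (0.27 log units; within the scatter), and that reading is clean for one simple reason: the fact that compounds 1 and 4 differ only in the configuration as drawn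

Phenethyl differs from pyridin-4-yl in both its ring and its chain, so these compounds cannot show which of the two differences goes with the longer half-life. Going by these compounds, a phenyl group at this place would separate them, and it remains open whether configuration matters as little with groups other than phenethyl.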